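Compound 1 and a Changed Benzyl Group on a Shared Core

The source may hold more compounds than are shown below. What is called first, only, known or untested is meant among the compounds shown, and "the series" means these compounds.

Compound 1 `Cc1c(C)c2ccc(OCC3CCN(Cc4ccc(CO)cc4)CC3)cc2oc1=O`: 29 nM
Compound 2 `Cc1cc2ccc(OCC3CCN(Cc4ccc(CO)cc4)CC3)cc2oc1=O`: 3100 nM

In an assay for inhibition of Amine oxidase [flavin-containing] B (Homo sapiens), read by fluorescence, using microsomes, with a stated time of 30 min (a higher number here means a weaker inhibitor, a lower number a stronger inhibitor), compound 1 gives 29 nM, the lowest of the two numbers shown, while compound 2 gives 3100 nM. Going by the values given here, the only measured step, a 110-fold higher number from compound 1 to compound 2 (2.03 log units; beyond the scatter), concerns the core of compound 1 and leaves the rest of the molecule untouched. Compound 3 `Cc1c(C)c2ccc(OCC3CCN(Cc4cccc(OCCCO)c4)CC3)cc2oc1=O` keeps the core of compound 1 intact and instead alters the group on the saturated chain carbon bound to the amine nitrogen in the ring: 3-(3-hydroxypropoxy)phenyl in place of 4-(hydroxymethyl)phenyl on a saturated chain carbon bound to an amine nitrogen in a ring. Among the compounds with values here, no measured step bears on this part of the molecule, so the expectation rests on compound 1 alone, with wide uncertainty. A modest step is expected, a 2.1-fold higher number from compound 1 to compound 3 (0.32 log units; beyond the scatter). Compound 3 is therefore estimated at 60 nM in this assay, within a range from 10 nM to 400 nM.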

Compound 3, half-maximal inhibitory concentration: 780 nM
Compound 3: the middle estimate sits 13-fold (1.11 log units) below what was measured; the measured number lies above the stated range.
By their numbers in this assay, from the lowest: compound 1; then compound 3; then compound 2.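

The group on the saturated chain carbon bound to an amine nitrogen in a ring is not a neutral spot: with the core of compound 1 kept intact, 3-(3-hydroxypropoxy)phenyl in place of 4-(hydroxymethyl)phenyl in this assay gives a 27-fold higher number from compound 1 to compound 3 (1.43 log units; beyond the scatter), so a change here, and not only on the core, moves the number beyond the scatter. The two groups differ in more than one feature, the entering group having 11 heavy atoms against 8 and 2 hydrogen-bond acceptors against 1, so this single step cannot be assigned to any one of them. No measurement at hand accounts for the step.

The compounds shown leave open how 3-(hydroxymethyl)phenyl or 4-(3-hydroxypropoxy)phenyl would read on the same core, which would separate the place of the substituent from its chain. Also open, going by these compounds, is whether the terminal hydroxyl matters, as against a plain propoxy chain or a terminal amine.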